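Acylating the ring amine of compound 2

This account rests on a few compounds, and the source may have more. Where it says the series, first, only, none or still open, it means among the compounds named here.

In a functional assay on U-87MG ATCC cells (Homo sapiens) for antiproliferative activity (a lower number here means a stronger inhibitor, a higher number a weaker inhibitor), compound 1 (`Cc1c2c(n3c1CCCN(C)[C@@H](C)[C@H](C)Nc1cc-3ccc1C(N)=O)CC(C)(C)CC2=O`) gives 133 nM, compound 2 (`Cc1c2c(n3c1CCN(C)C[C@@H](C)[C@H](C)Nc1cc-3ccc1C(N)=O)CC(C)(C)CC2=O`) gives 49 nM and compound 3 (`CC(=O)N1CCCc2c(C)c3c(n2-c2ccc(C(N)=O)c(c2)N[C@@H](C)[C@@H]1C)CC(C)(C)CC3=O`) gives 29 nM. Compound 2 lies within the scatter of compound 3 and beyond the scatter on the lower side of compound 1. Compound 4 (`Cc1c2c(n3c1CCN(C(=O)[C@@H](N)C(C)C)C[C@@H](C)[C@H](C)Nc1cc-3ccc1C(N)=O)CC(C)(C)CC2=O`) carries (1-amino-2-methylpropyl)carbonyl in place of methyl on an amine nitrogen in a ring. Going by the values given here, the only measured step of this kind, a 4.6-fold lower number from compound 1 to compound 3 (0.66 log units; beyond the scatter), is acetyl in place of methyl, with a different group on a different parent. A smaller shift in the same direction is therefore expected, possibly within the scatter: a 1.6-fold lower number from compound 2 to compound 4 (0.21 log units; within the scatter). The estimated value for compound 4 is 30 nM, with an expected range of 9 nM to 100 nM.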

Compound 4, half-maximal inhibitory concentration: 48 nM
Compound 4: middle estimate off by 1.6-fold (0.20 log units), on the low side; low and high end bracket the measured number.
By their numbers in this assay, from the lowest: compounds 3, 4 and 2 (each within the scatter of the next); then compound 1.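

On the amine nitrogen in the ring, (1-amino-2-methylpropyl)carbonyl in place of methyl leaves the number in this assay within the scatter (a 1.0-fold lower number from compound 2 to compound 4 (0.01 log units; within the scatter)), so this position accepts a substituted acyl group that also brings a hydrogen-bond donor. Going by these compounds alone, the step beyond the scatter seen with acetyl on a different parent (a 4.6-fold lower number from compound 1 to compound 3 (0.66 log units; beyond the scatter)) has no counterpart with this group on compound 2. No measurement shown accounts for this result.

Open, as far as these compounds go, is whether a propionyl or a methanesulfonyl group on this nitrogen would stay within the scatter of compound 2. From the compounds shown here alone, the effect of the free amine in the entering group also remains open, and a hydroxyl in its place would test this.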